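Ortho Fluoro for Methyl on the Aryl Ether Ring

This account rests on a few compounds, and the source may have more. Where it says the series, first, only, none or still open, it means among the compounds named here.

Compound 3 `Cc1ccccc1Oc1ccc(N2CCC[C@H]2CC(=O)O)cc1` gives 74 nM in a functional assay on cells for agonist activity at Free fatty acid receptor 1 (Homo sapiens), read by FLIPR and calcium flux, with a stated time of 100 s (a higher number here means that more compound is needed for the effect, a lower number that less compound is needed), the second highest of the three numbers shown. Compound 1 `Cc1ccccc1Oc1ccc(N2C[C@@H](C(F)(F)F)C[C@H]2CC(=O)O)cc1` gives 73 nM, and the step of a 1.0-fold higher number from compound 1 to compound 3 (0.01 log units; within the scatter) lies within the scatter. Compound 2 `O=C(O)C[C@H]1CCN1c1ccc(OCc2ccc(Cl)cc2Cl)cc1` gives 13000 nM, a number far above the other two. Compound 4 `O=C(O)C[C@@H]1CCCN1c1ccc(Oc2ccccc2F)cc1` differs from compound 3 by fluoro in place of methyl on an aromatic carbon. Within the data shown here, no measured step touches the aromatic ring where this change sits; the only step known, from compound 1 to compound 3, concerns a saturated ring carbon and stayed within the scatter. It is therefore expected that the step of a 1.4-fold higher number from compound 3 to compound 4 (0.13 log units; within the scatter) also remains within the scatter. Compound 4 is expected to give about 100 nM, in a range from 35 nM to 300 nM.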

Compound 4, half-maximal effective concentration: 150 nM
Estimate against measurement, compound 4: 1.5-fold (0.18 log units) below; measured number inside the range.
By their numbers in this assay, from the lowest: compounds 1 and 3 (each within the scatter of the next); then compound 4; then compound 2.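

With fluoro in place of methyl, the change from 2-methylphenyl to 2-fluorophenyl gives a step beyond the scatter in this assay (a 2.0-fold higher number from compound 3 to compound 4 (0.31 log units; beyond the scatter)), though a modest one. This position, ortho to a large group, therefore responds to a one-atom exchange, unlike the saturated ring carbon of the earlier step (a 1.0-fold higher number from compound 1 to compound 3 (0.01 log units; within the scatter)). Nothing available accounts for this rise. From the compounds shown here alone, whether chloro, methoxy or plain hydrogen here would stand nearer compound 3 or compound 4 remains open. So does whether the change behaves alike on the trifluoromethyl-bearing core of compound 1.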